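From Methoxy to Cyano at Compound 4

A few compounds are considered here, and "the series" means these few. Any claim that something is new, unique, unknown or untested is made for them only; others in the source may bear on it.

In a functional assay on MCF7 cells (Homo sapiens) for inhibition, read by MTT assay, with a stated time of 72 h (a higher number here means a weaker inhibitor, a lower number a stronger inhibitor), compound 1 `C/C=C/C(=O)Nc1cccc(Oc2nc(Nc3cccc(OC)c3)nc3ccsc23)c1` gives 14600 nM. Compound 2 `COc1cccc(Nc2nc(Oc3cccc(NC(=O)C=C(C)C)c3)c3sccc3n2)c1` gives 35800 nM, and compound 3 `COc1cccc(Nc2nc(Oc3cccc(NC(=O)/C=C/C(C)C)c3)c3sccc3n2)c1` gives 43900 nM. These three differ only in the group on the carbonyl carbon. Compound 3 cannot be told apart from its closest neighbour on the numbers, with a 1.2-fold higher number from compound 2 to compound 3 (0.09 log units; within the scatter). Its gap to the remaining compound is wider, with a 3.0-fold higher number from compound 1 to compound 3 (0.48 log units; beyond the scatter), and a similar gap appears in a 2.5-fold higher number from compound 1 to compound 2 (0.39 log units; beyond the scatter).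

Compound 4 `CC(C)/C=C/C(=O)Nc1cccc(Oc2nc(Nc3cccc(C#N)c3)nc3ccsc23)c1` keeps the carbonyl side of compound 3 and changes a different place: cyano in place of methoxy on an aromatic carbon. Put simply, 3-methoxyphenyl becomes 3-cyanophenyl, with cyano in place of methoxy on an aromatic carbon.

Within the data shown here, no measured step touches this place. Among the measured compounds shown here, the three steps above show only that changes elsewhere in this small set were modest or lay within the scatter, so they give no direction for the new swap. With nothing pointing either way, no step beyond the scatter is expected in this assay. The expected change is a 1.3-fold lower number from compound 3 to compound 4 (0.10 log units; within the scatter). Compound 4 is estimated at 35000 nM, with an expected range from 13000 nM to 80000 nM.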

Compound 4, half-maximal inhibitory concentration: > 50000 nM
Compound 4: no number, only a limit (the forecaster's own chance of this, stated with the estimate: 10%); at least 1.4-fold (0.15 log units) between middle value and limit.
By their numbers in this assay, from the lowest: compound 1; then compounds 2 and 3 (each within the scatter of the next). At a limit, above all of these: compound 4.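

In this assay compound 4 gives > 50000 nM, which is a limit of the assay and not a number. Among these compounds, until now every compound carried 3-methoxyphenyl, so this is the first reading of a change at that place, and an at least 1.1-fold higher number from compound 3 to compound 4 (0.05 log units; that floor lies within the scatter) shows that cyano in place of methoxy, with the same count of heavy atoms and hydrogen-bond acceptors on each side, brought no stronger inhibition. That floor lies within the scatter, so the size of the step stays unknown, and the result cannot say whether this swap changes the number at all or pushes it far higher: the limit of > 50000 nM in this assay, at which 1 of the 4 values shown sits.

Only methoxy and cyano appear at this place, and a hydroxyl, an amine or a carboxylic acid there could move the number in either direction. On these data alone, it also stays open how cyano would read alongside the carbonyl side of compound 1, which has the lowest number of the set at 14600 nM. A measured number there could give the swap a real size.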